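Removing the Methoxy Group from Compound 1

The source may report more compounds than this note shows. Statements on the series, on what has been measured and on what is new or still open speak of the compounds shown alone.

Compound 1 `COc1ccc(CC2CCCCN2C(=O)n2ncc(C(O)(c3ccc(F)cc3)c3ccc(F)cc3)n2)cc1` has been measured in an assay on isolated protein for inhibition of Monoacylglycerol lipase ABHD6 (Homo sapiens), read by fluorescence (on this read-out higher numbers stand for weaker inhibition and lower numbers for stronger inhibition), and gives 251 nM. Compound 2 `O=C(N1C[C@@H](O)C=C[C@@H]1Cc1ccccc1)n1ncc(C(O)(c2ccc(F)cc2)c2ccc(F)cc2)n1`, which carries its benzyl group on a different saturated ring, gives 251 nM in this assay. The two numbers agree at the digits shown, so nothing separates compound 1 from compound 2 beyond the usual scatter of this measurement, and compound 1 stands level with compound 2 on the numbers available.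

Compound 3 `O=C(N1CCCCC1Cc1ccccc1)n1ncc(C(O)(c2ccc(F)cc2)c2ccc(F)cc2)n1` has not yet been measured. Compared with compound 1, (hydrogen in place of methoxy on an aromatic carbon), that is, hydrogen in place of methoxy on an aromatic carbon: the 4-methoxybenzyl of compound 1 becomes a plain benzyl. Going by the values given here, no measured pair shows this exact change, so its size has to be guessed. The fact that compound 1 and compound 2 sit at the same level despite a changed ring suggests that this region tolerates alteration, so only a small step is expected, if any, leaning toward slightly weaker inhibition. Compound 3 is expected to give about 400 nM, with a range from 150 nM to 1000 nM. The expected step of a 1.6-fold higher number from compound 1 to compound 3 (0.20 log units; within the scatter) is estimated to be modest and may fall within the scatter.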

Compound 3, half-maximal inhibitory concentration: 25.1 nM
The estimate for compound 3 lay 16-fold (1.20 log units) above the measured number; the measured number lies below the stated range.
By their numbers in this assay, from the lowest: compound 3; then compounds 1 and 2 (each within the scatter of the next).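

In this assay the loss of the methoxy from the 4-methoxybenzyl group gives a 10-fold lower number from compound 1 to compound 3 (1.00 log units; beyond the scatter) and this step lies beyond the scatter, so here the plain benzyl goes with clearly stronger inhibition. Compound 1 and compound 2 differ in more than one place, so their matching values could say nothing about this one position; the new pair isolates it and shows that the aromatic carbon para to a large group is far from indifferent, since exchanging a methoxy of 2 heavy atoms for hydrogen is enough to move the number well beyond the usual scatter. Nothing measured among these compounds says why so limited a change in structure has this effect.

Open, on these data alone, is whether hydrogen is the best choice at this carbon, or whether a fluorine, a hydroxyl, an amine or a longer ether chain would give a number closer to that of compound 1 or that of compound 3. Also open, as far as these compounds go, is whether the same exchange would have a similar effect on a compound with the ring of compound 2, which carries no methoxy to remove, so that a methoxy would have to be added to it for the comparison.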